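The source may report more compounds than this note shows. Statements on the series, on what has been measured and on what is new or still open speak of the compounds shown alone.

- Compound 1 `CCO[C@H]1C[C@@H](c2coc3ccc(F)cc3c2=O)N(c2ccccc2)O1`: > 60000 nM, a limit of the assay and not a number
- Compound 2 `O=c1c([C@@H]2C[C@H](c3ccccc3)ON2c2ccccc2)coc2ccc(Br)cc12`: 60000 nM
- Compound 3 `CCO[C@H]1C[C@@H](c2coc3ccc(C)cc3c2=O)N(c2ccccc2)O1`: 41000 nM

All three values come from a functional assay on THP-1 cells (Homo sapiens) for inhibition, read by sulforhodamine B assay, with a stated time of 48 h; on this read-out lower numbers stand for stronger inhibition and higher numbers for weaker inhibition. Only compound 2 and compound 3 have actual numbers, and these two lie within the scatter of each other. Compound 3 therefore stands level with compound 2 in this small set, and both need high concentrations to reach the half-way point.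

The next step leads to compound 4 `CCO[C@H]1C[C@@H](c2coc3ccc(Br)cc3c2=O)N(c2ccccc2)O1`, where bromo takes the place of methyl on an aromatic carbon (bromo in place of methyl on an aromatic carbon). Among the compounds with values here, no measured step covers this exact swap. The closest is the exchange of fluoro for methyl, an at least 1.4-fold lower number from compound 1 to compound 3 (0.16 log units; that floor lies within the scatter), so changing the group at this spot has so far shown no effect beyond the scatter. Compound 2 also carries a bromo group and gives 60000 nM, which offers no sign of a large gain. The upper end also needs care, given (the limit of > 60000 nM in this assay, at which 1 of the 3 values shown sits), so compound 4 may return only a limit.

In this assay, the expected step is a 1.2-fold higher number from compound 3 to compound 4 (0.07 log units; within the scatter), which means no change beyond the scatter is expected. The estimate for compound 4 is 48000 nM, with an expected range from 24000 nM to 60000 nM.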

Compound 4, half-maximal inhibitory concentration: > 60000 nM
Compound 4: only a limit was reported (the forecaster's own chance of this, stated with the estimate: 35%); middle value at least 1.2-fold (0.09 log units) away from the limit.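

In this assay compound 4 gives > 60000 nM, which is a limit of the assay and not a number. Swapping methyl for bromo on this aromatic carbon gives an at least 1.4-fold higher number from compound 3 to compound 4 (0.16 log units; that floor lies within the scatter), so the step has only a lower bound, and its true size stays unknown. Ethoxy in place of phenyl on a saturated ring carbon gives a number no lower from compound 2 to compound 4 (the limit leaves the size open) and no more than that can be read. With fluoro in compound 1, methyl in compound 3 and bromo in compound 4, only the methyl compound has an actual number, yet the steps at this position show nothing beyond the scatter, the step reaching compound 4 from compound 1 cannot be read, and the top of the measurable range now limits what this small set can say: the limit of > 60000 nM in this assay, at which 2 of the 4 values shown sit.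

Going by these compounds, it remains open how far compound 4 really lies from compound 3, and whether bromo makes any true difference at this position. The compounds shown also leave open whether a quite different group on this aromatic carbon, such as an amine, a carboxylic acid or a longer chain, would bring the number clearly below those of compound 2 and compound 3.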